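Replacing the aryl group on the ring nitrogen

The source may report more compounds than this note shows. Statements on the series, on what has been measured and on what is new or still open speak of the compounds shown alone.

Of the compounds shown here, two sharing one core have been measured in a functional assay on A549 cells (Homo sapiens) for inhibition, read by MTT assay, with a stated time of 72 h; on this read-out higher numbers stand for weaker inhibition and lower numbers for stronger inhibition. Compound 1 `O=C(Nc1ccc(Oc2ccnc3[nH]ccc23)cc1)c1cn(-c2ccc(F)cc2)c2ccccc2c1=O` carries a 4-fluorophenyl on an aromatic nitrogen, and in this assay compound 1 gives 390 nM. For the measured compounds named here, compound 2 `O=C(Nc1ccc(Oc2ccnc3[nH]ccc23)cc1)c1cn(-c2ccc(C(F)(F)F)cc2Cl)c2ccccc2c1=O` carries a 2-chloro-4-(trifluoromethyl)phenyl at the same place, and in this assay compound 2 gives 2350 nM, the highest of the two numbers; the only step reaching it is a 6.0-fold higher number from compound 1 to compound 2 (0.78 log units; beyond the scatter), a change toward weaker inhibition. Compound 3 `O=C(Nc1ccc(Oc2ccnc3[nH]ccc23)cc1)c1cn(-c2ccc(F)c(Cl)c2)c2ccccc2c1=O` has not yet been measured. It differs from compound 2 as follows: 3-chloro-4-fluorophenyl in place of 2-chloro-4-(trifluoromethyl)phenyl on an aromatic nitrogen. The entering group has fewer heavy atoms than the one it replaces and, like the group of compound 1, contains a fluorine, but it also keeps a chlorine, so the step from compound 1 to compound 2 gives only a partial guide. Compound 3 is therefore expected to land between the two measured numbers, with an estimated step of a 3.1-fold lower number from compound 2 to compound 3 (0.50 log units; beyond the scatter). For compound 3 the estimate in this assay is 750 nM, with a likely range from 250 nM to 2200 nM.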

Compound 3, half-maximal inhibitory concentration: 4810 nM
The estimate for compound 3 lay 6.4-fold (0.81 log units) below the measured number; the whole stated range lies below it.
By their numbers in this assay, from the lowest: compound 1; then compound 2; then compound 3.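

Adding a single chloro to the 4-fluorophenyl of compound 1 produces compound 3, and in this assay this one small addition gives a 12-fold higher number from compound 1 to compound 3 (1.09 log units; beyond the scatter). For the compounds shown here, that is the first view of this position in which only one atom changes, and it shows that the number here responds strongly to a single chloro on the aryl ring. Moving to the group with fewer heavy atoms also brings no recovery, since the swap of the 2-chloro-4-(trifluoromethyl)phenyl for the 3-chloro-4-fluorophenyl gives a 2.0-fold higher number from compound 2 to compound 3 (0.31 log units; beyond the scatter), so among these three compounds the smaller group does not have the lower number, and nothing available accounts for either step.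

Compound 2 and compound 3 differ both in where the chloro sits and in whether a trifluoromethyl or a fluoro is present, so the contribution of each cannot be separated. From the compounds shown here alone, it also remains open whether a plain phenyl, or an aryl ring carrying a methoxy group or an amine, would give a lower number than compound 1 or continue the rise seen with chloro.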